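The compounds below may be only part of what the source reports. "The series", "measured", "known", "first", "only" and "open" are said of these compounds alone.

Compound 2 `O=C(OCC(O)CO)c1nn(Cc2cc(Cl)cc(Cl)c2)c2ccccc12` is the smallest ester of the set, its acyl group fixed to a 1,2-dihydroxyethyl-bearing carbinol. Among the compounds with values here, in a physicochemical assay for lipophilicity (a lower number here means a more polar compound, a higher number a more lipophilic compound), compound 2 gives 3.96, the highest of the three numbers measured so far. Compound 1 `O=C(OC(C(O)CO)C(OC(=O)c1nn(Cc2cc(Cl)cc(Cl)c2)c2ccccc12)C(O)CO)c1nn(Cc2cc(Cl)cc(Cl)c2)c2ccccc12`, which carries two of the same acyl groups on an open-chain polyol, gives in this assay a partition coefficient of 3.52, lower than compound 2 by more than the usual scatter. Compound 3 `O=C(OC[C@H]1O[C@@H](O)[C@H](O)[C@H]1OC(=O)c1nn(Cc2cc(Cl)cc(Cl)c2)c2ccccc12)c1nn(Cc2cc(Cl)cc(Cl)c2)c2ccccc12`, again with two acyl groups but on a five-membered sugar ring, stands furthest away: in this assay compound 3 gives 2.86, also beyond the scatter from compound 2.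

Compound 4 `O=C(OC[C@H]1OC(O)[C@H](O)[C@@H](O)[C@H]1O)c1nn(Cc2cc(Cl)cc(Cl)c2)c2ccccc12` has not yet been measured. It differs from compound 2 in one place: 3,4,5,6-tetrahydroxyoxan-2-yl in place of 1,2-dihydroxyethyl on a saturated chain carbon bound to an oxygen next to a carbonyl group. Within the data shown here, no pair of measured compounds isolates this exact exchange, so its size cannot be read directly; what the numbers do show is that every compound bearing more hydroxyl-rich framework than compound 2 sits lower, and compound 3 sits lowest. A decrease beyond the scatter is therefore expected for compound 4. For compound 4 the expected step is a number 1.36 log units lower from compound 2 to compound 4 (beyond the scatter). Compound 4 is estimated at 2.6, with a plausible range from 1.9 to 3.3.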

Compound 4, partition coefficient: 2.54
Compound 4: the middle estimate sits 0.06 log units above what was measured; measured number inside the range.
By their numbers in this assay, from the lowest: compound 4; then compound 3; then compound 1; then compound 2.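

In this assay the exchange of 1,2-dihydroxyethyl for 3,4,5,6-tetrahydroxyoxan-2-yl on a saturated chain carbon bound to an oxygen next to a carbonyl group gives a number 1.42 log units lower from compound 2 to compound 4 (beyond the scatter), a large step and the first in this set that can be read for a change in one place. Compound 1 and compound 3 each carry two acyl groups on a different framework, so neither could show what this position does alone; the new step shows that the number falls beyond the scatter with a single acyl group and the rest of the ester unchanged. The entering group brings one six-membered non-aromatic ring, more heavy atoms and more hydrogen-bond donors and acceptors all at once, and nothing at hand accounts for the size of the step.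

The compounds shown leave open how much of the step goes with the ring and how much with the hydroxyl groups on it. From the compounds shown here alone, an open-chain pentitol group, a methoxy group in place of a ring hydroxyl, or an amine or a carboxylic acid on the same ring could separate these contributions, and their effect at this position remains unknown.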